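This account rests on a few compounds, and the source may have more. Where it says the series, first, only, none or still open, it means among the compounds named here.

Compound 1 `COC(=O)c1cn2ccncc2n1`: > 34 nM
Compound 2 `CCOC(=O)c1c(C)nc2cnccn12`: 19 nM
Compound 3 `CCOC(=O)c1[nH]c2nccnc2c1C`: 24 nM

All three results come from a functional assay on the whole organism for inhibition, with Cavia porcellus as the target; a lower number here means that less compound is needed, a higher number that more compound is needed for the effect. Compound 1 has no exact number, only a limit of the assay: > 34 nM. Compound 2 and compound 3 both gave numbers, and these lie within the usual scatter of each other, so neither can be ranked above the other.

Compound 4 `N#Cc1cn2ccncc2n1` keeps the core of compound 1 and changes one group: cyano in place of methoxycarbonyl on an aromatic carbon. For the measured compounds named here, no pair of measured compounds shows this swap or any other single change, so there is no direct guide to its effect. The safest expectation in this assay is therefore no shift beyond the scatter, in either direction. The estimated change is a step that the limit leaves unreadable from compound 1 to compound 4. For compound 4 the expected value is 40 nM, with an estimated range of 12 nM to 150 nM.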

Compound 4, concentration for half-maximal effect: > 167 nM
Compound 4 was reported as a limit; the forecaster's own chance of this, stated with the estimate: 40%; middle value at least 4.1-fold (0.62 log units) away from the limit.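

Compound 1 and compound 4 are both reported in this assay only as limits, so the step between them, cyano in place of methoxycarbonyl on an aromatic carbon, cannot be read. The compounds shown leave open how large this swap's effect is, and its direction.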